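Extending a Methyl to a Propargyl Group

This account rests on a few compounds, and the source may have more. Where it says the series, first, only, none or still open, it means among the compounds named here.

Of the compounds shown here, two have been measured in an assay on isolated protein for inhibition of Dihydrofolate reductase (Homo sapiens), read by spectrophotometry; a higher number here means a weaker inhibitor, a lower number a stronger inhibitor. Compound 1 `CN(Cc1nc2cc(C(F)(F)F)ccc2nc1-c1ccccc1)c1ccc(Cl)cc1` gives 5000 nM there. Compound 2 `COc1ccc(N(C)Cc2nc3cc(C(F)(F)F)ccc3nc2-c2ccccc2)cc1` gives 3000 nM in this assay. Compound 1 holds the higher of the two numbers, but the step of a 1.7-fold lower number from compound 1 to compound 2 (0.22 log units; within the scatter) is within the scatter, so the two compounds cannot be told apart on these data. Compound 3 `C#CCN(Cc1nc2cc(C(F)(F)F)ccc2nc1-c1ccccc1)c1ccc(Cl)cc1` has not yet been measured. It differs from compound 1 by ethynyl in place of hydrogen on a saturated chain carbon bound to a nitrogen on an aromatic ring; cut one bond further out, the same change reads methyl to propargyl. For the measured compounds named here, no measured step bears on this part of the molecule: the only known step, a 1.7-fold lower number from compound 1 to compound 2 (0.22 log units; within the scatter), swaps a group on an aromatic carbon and says nothing about the chain on the nitrogen. There is therefore no ground for expecting a step beyond the scatter in this assay in either direction. Compound 3 is expected to give about 5000 nM, in a range from 1500 nM to 16000 nM. That estimate corresponds to an expected step of no change at the digits printed from compound 1 to compound 3 (within the scatter).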

Compound 3, inhibition constant: 4000 nM
Compound 3: the middle estimate sits 1.3-fold (0.10 log units) above what was measured; measured number inside the range.
By their numbers in this assay, from the lowest: compounds 2, 3 and 1 (each within the scatter of the next).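

For the compounds shown here, replacing methyl with propargyl on the nitrogen gives in this assay a 1.3-fold lower number from compound 1 to compound 3 (0.10 log units; within the scatter) and so gives the first reading at this part of the molecule, which compounds 1 and 2 could not provide. At this position, ethynyl in place of hydrogen on the saturated chain carbon produces no difference that can be told from the ordinary spread of repeated measurements. No independent measurement bears on why the number stays within that spread.

Going by these compounds, whether a longer chain on this nitrogen, or a chain ending in an amine or a carboxylic acid, would give a step beyond the scatter remains open. Also open, on these data alone, is how the propargyl group would read alongside the methoxy group of compound 2.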